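The compounds below may be only part of what the source reports. "The series", "measured", "known", "first", "only" and "open" are said of these compounds alone.

In a functional assay on MCF7 cells (Homo sapiens) for inhibition, read by resazurin assay, with a stated time of 72 h (on this read-out lower numbers stand for stronger inhibition and higher numbers for weaker inhibition), compound 3 (`CCSc1ccc(C2C(O)C(=O)N2c2cc(OC)c(OC)c(OC)c2)cc1`) gives 6 nM, within the scatter of compound 1 (`COc1ccc(C2C(O)C(=O)N2c2cc(OC)c(OC)c(OC)c2)cc1`) at 4 nM. Compound 2 (`CCSc1ccc(C2C(Oc3ccccc3)C(=O)N2c2cc(OC)c(OC)c(OC)c2)cc1`) stands well apart at 210 nM.

The next change keeps the hydroxy group of compound 3 and replaces the aromatic group, giving compound 4 (`COc1ccc(C2C(O)C(=O)N2c2cc(OC)c(OC)c(OC)c2)cc1O`): 3-hydroxy-4-methoxyphenyl in place of 4-(ethylsulfanyl)phenyl on a saturated ring carbon. In words, 3-hydroxy-4-methoxyphenyl replaces 4-(ethylsulfanyl)phenyl on a saturated ring carbon.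

Among the measured compounds shown here, the one measured step on this aromatic ring is ethylsulfanyl in place of methoxy, which gave a 1.5-fold higher number from compound 1 to compound 3 (0.18 log units; within the scatter). The large step, a 35-fold lower number from compound 2 to compound 3 (1.54 log units; beyond the scatter), concerns the group on oxygen at the saturated carbon, which is not altered here, so it offers little guidance. For the measured compounds named here, no measured compound carries a hydroxy group on the aromatic ring, so that part of the change remains untested.

With only the small step as a guide, no change beyond the scatter is expected: the estimated step is a 1.2-fold lower number from compound 3 to compound 4 (0.08 log units; within the scatter). The expected value for compound 4 is 5 nM, with an estimated range of 1.5 nM to 20 nM.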

Compound 4, half-maximal inhibitory concentration: 3 nM
Compound 4: middle estimate off by 1.7-fold (0.22 log units), on the high side; the range from low to high includes it.
By their numbers in this assay, from the lowest: compounds 4, 1 and 3 (each within the scatter of the next); then compound 2.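

In this assay, the first measured aromatic hydroxy group leaves the number within the scatter: adding hydroxy to the aromatic ring of compound 1 gives a 1.3-fold lower number from compound 1 to compound 4 (0.12 log units; within the scatter). Replacing 4-(ethylsulfanyl)phenyl with 3-hydroxy-4-methoxyphenyl on the saturated ring carbon gives a 2.0-fold lower number from compound 3 to compound 4 (0.30 log units; within the scatter), also within the scatter, so the three aryl groups in compounds 1, 3 and 4 cannot be told apart in this assay while the hydroxy group on the four-membered ring is kept. No supporting data are available to explain this lack of separation.

Still open, on these data alone, is how an amine or a carboxylic acid would behave in place of the aromatic hydroxy group, or a longer chain in place of ethyl on the sulfur. Also open, as far as these compounds go, is whether a phenyl group on the saturated-carbon oxygen would cost as much with 3-hydroxy-4-methoxyphenyl as it does with 4-(ethylsulfanyl)phenyl.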